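The compounds below may be only part of what the source reports. "The series", "measured", "known", "first", "only" and "open" are said of these compounds alone.

Compound 1 `CCOC(=O)c1cnn(CC(C)O)c1NC(=O)Nc1ccc(F)cc1` carries a 4-fluorophenyl on an amide-type nitrogen of the shared core. In a functional assay on cells (Neutrophil, Homo sapiens) for inhibition, with a stated time of 10 min (a higher number here means a weaker inhibitor, a lower number a stronger inhibitor), compound 1 gives only a limit of the assay, > 10 nM, so its true place on the scale is not fixed. The one companion measured in this assay is compound 2 `CCOC(=O)c1cnn(CC(O)CC)c1NC(=O)Nc1ccccc1F`, which gives 120 nM. Among the compounds with values here, compound 1 thus sits on a limit line the limit of > 10 nM in this assay, at which 1 of the 2 values shown sits, and no measured step sets off from it. Compound 3 `CCOC(=O)c1cnn(CC(C)O)c1NC(=O)NC(C)C` differs from compound 1 in one place: isopropyl in place of 4-fluorophenyl on an amide-type nitrogen. Within the data shown here, no measured step of this kind is in hand, so the size of the change is open. The expected step from compound 1 to compound 3 in this assay is a step that the limit leaves unreadable from compound 1 to compound 3, a loss beyond the usual scatter. Compound 3 is accordingly estimated at 1500 nM in this assay, with a range from 300 nM to 8000 nM.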

Compound 3, half-maximal inhibitory concentration: 90 nM
Estimate against measurement, compound 3: 17-fold (1.22 log units) above; the measured number lies below the stated range.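

In this assay no step can be read between compound 1 and compound 3. Compound 1 gives only the limit > 10 nM as its value. The compounds shown leave open how isopropyl in place of 4-fluorophenyl on an amide-type nitrogen alters inhibition, in size or in direction.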